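Adding oxan-4-yl to the chain of compound 1

The compounds below may be only part of what the source reports. "The series", "measured", "known", "first", "only" and "open" are said of these compounds alone.

- compound 1 `CCN1CCN(c2nc(C)nc3c2nc(-c2ccccc2Cl)n3C)CC1`: 7%
- compound 2 `Cc1nc(N2CCN(C)CC2)c2nc(-c3ccccc3Cl)n(CCO)c2n1`: 13%
- compound 3 `Cc1nc(N2CCN(C)CC2)c2nc(-c3ccccc3Cl)n(CCN3CCCC3=O)c2n1`: 13%

These values come from an ADME assay (liver) for metabolic stability, with Liver microsome (Homo sapiens) as the target, read by LC-MS, using microsomes, with a stated time of 30 min, tested at 4 uM; on this read-out lower numbers stand for a less stable compound and higher numbers for a more stable compound. Compound 1 cannot be told apart from compound 2 or compound 3, since its gaps to both lie within the scatter.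

Compound 4 `CCN1CCN(c2nc(C)nc3c2nc(-c2ccccc2Cl)n3CC2CCOCC2)CC1` carries oxan-4-yl in place of hydrogen on a saturated chain carbon bound to an aromatic nitrogen. Going by the values given here, only one measured step touches a chain on an aromatic nitrogen: no change at the digits printed from compound 2 to compound 3 (within the scatter), where 2-oxopyrrolidin-1-yl took the place of hydroxy. This single step offers only loose guidance, but it gives no reason to expect a shift beyond the scatter in this assay. The expected step is a number 5 percentage points higher from compound 1 to compound 4 (within the scatter), an estimate within the scatter. For compound 4 the estimated value is 12%, expected to fall between 3% and 30%.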

Compound 4, percent of the compound remaining in the Liver microsome assay: 41%
For compound 4 the middle estimate is 29 percentage points below the measured one; the whole stated range lies below it.
By their numbers in the Liver microsome assay, from the lowest: compounds 1, 2 and 3 (each within the scatter of the next); then compound 4.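

Going by these compounds alone, in the Liver microsome assay, oxan-4-yl in place of hydrogen on a saturated chain carbon bound to an aromatic nitrogen gives a number 34 percentage points higher from compound 1 to compound 4 (beyond the scatter), with compound 1 at 7% and compound 4 at 41%, so a change at this position can move this read-out beyond the scatter, which the earlier compounds did not show. In a physicochemical assay for lipophilicity (on this read-out higher numbers stand for higher lipophilicity and lower numbers for lower lipophilicity), the same change gives a number 0.30 log units higher from compound 1 to compound 4 (within the scatter), with compound 1 at 3.1 and compound 4 at 3.4. Nothing measured here bears on why the number rises. The compounds shown leave open whether the ring oxygen of oxan-4-yl matters. Cyclohexyl on the same carbon would test this, and piperidin-4-yl, which holds an amine in the ring, would extend the comparison.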